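Three Chlorinated Ureas Measured, a Fourth Awaiting Its Number

A few compounds are considered here, and "the series" means these few. Any claim that something is new, unique, unknown or untested is made for them only; others in the source may bear on it.

The study covers a small set of compounds sharing one core. Compound 1 `C[C@@H](NC(=O)Nc1ccccc1Cl)c1ccccc1` and compound 2 `C[C@H](NC(=O)Nc1ccccc1Cl)c1ccccc1` are the pair that anchors it: the two have the same atoms and bonds and differ only as described here, (the two compounds have the same atoms and bonds and differ only in configuration as drawn: 1 of 1 stereo elements differ; a stereocentre at a saturated chain carbon is drawn S in compound 2 and R in compound 1). In an ADME assay on the whole organism with Oryza sativa as the target, tested at 0.1 uM (a higher number here means a weaker effect of the compound at the concentration tested, a lower number a stronger effect), compound 1 gives 101%, and compound 2 gives 99%. The step of a number 2 percentage points lower from compound 1 to compound 2 (within the scatter) is the kind of step one would expect to be small because of the fact that compounds 1 and 2 differ only in the configuration as drawn.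

Compound 3 `C[C@H](NC(=O)Nc1ccc(Cl)cc1Cl)c1ccccc1` carries one change relative to compound 2, namely (chloro in place of hydrogen on an aromatic carbon). In this assay compound 3 gives 100%, so that the step of a number 1 percentage points higher from compound 2 to compound 3 (within the scatter) stays inside the scatter of the measurement. Compound 1 holds the highest of the three numbers, but neither compound 3 nor compound 2 is separated from it by more than the scatter, so no ordering among the three can be read from these values.

Compound 4 `C[C@@H](NC(=O)Nc1c(Cl)cccc1Cl)c1ccccc1` has not yet been measured. It differs from compound 1 by chloro in place of hydrogen on an aromatic carbon. This is the same kind of change as that from compound 2 to compound 3, though not the same change, since the chloro group in compound 4 sits ortho to a large group and meta to a chloro group, whereas in compound 3 it sits meta to a chloro group and para to a large group. Given that the comparable step from compound 2 to compound 3 stayed within the scatter, the step of a number 1 percentage points lower from compound 1 to compound 4 (within the scatter) from compound 1 to compound 4 in this assay is expected to be small as well. Compound 4 is therefore estimated to give 100% in this assay, with a range from 91% to 108%.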

Compound 4, a percentage reported as activity, at one concentration (the size of the read-out at that concentration, not a potency): 100%
For compound 4 middle estimate and measured number coincide at the digits printed, within the range that was stated.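

In this assay, chloro in place of hydrogen on an aromatic carbon gives a number 1 percentage points lower from compound 1 to compound 4 (within the scatter). Set beside the earlier step, the same change shows no difference between the two cores that could be told from the scatter of the measurement: the same change on two cores in this assay, a number 1 percentage points higher (within the scatter) from compound 2 to compound 3 and a number 1 percentage points lower (within the scatter) from compound 1 to compound 4, 2 percentage points apart, within the scatter of two such steps. Going by these compounds alone, this shows only that on these two cores, which also differ in configuration as drawn, the added chloro leaves the number within the scatter, but it does not show a measurable effect being carried from one core to the other, since neither step has a size that can be separated from the scatter, and the chloro does not stand in the same place in the two steps.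

The compounds shown leave open whether a group other than chloro on the aromatic ring, such as a methoxy group, a nitrile or an amine, or a longer chain in place of the methyl group on the saturated chain carbon, would move the number in this assay beyond the scatter. They also leave open whether the two chloro steps would stay this small at a higher concentration, and whether a step of real size, once seen on one core, would carry over to the other.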